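The compounds below may be only part of what the source reports. "The series", "measured", "known", "first", "only" and "open" are said of these compounds alone.

Working notes on the series, with values in a physicochemical assay for lipophilicity (on this read-out lower numbers stand for lower lipophilicity and higher numbers for higher lipophilicity), as measured so far:

- compound 1 `CCn1cnc2c(-c3ccc(F)c(-c4cccnc4)c3)cnnc21` gives 2.6
- compound 2 `CCn1cnc2c(-c3ccc(F)c(Oc4ccnc(C)c4)c3)cnnc21` gives 2.6
- compound 3 `CCn1cnc2c(-c3ccnc(Oc4ccccc4)c3)cnnc21` gives 2.6

Compound 2 stands level with both compound 1 and compound 3 on these numbers. The next compound to read is compound 4 `CCn1cnc2c(-c3ccc(F)c(OCc4ccccn4)c3)cnnc21`, reached by (pyridin-2-yl)methyl in place of 2-methylpyridin-4-yl on an oxygen on an aromatic ring with the same atoms, joined differently. Cut one bond further out, the change reads (2-methylpyridin-4-yl)oxy to (pyridin-2-yl)methoxy.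

For the measured compounds named here, no measured pair shows this exact exchange. The nearest evidence is no change at the digits printed from compound 1 to compound 2 (within the scatter) on placing (2-methylpyridin-4-yl)oxy where pyridin-3-yl stood on an aromatic carbon, and the three measured compounds share one value at the digits shown. Accordingly the expected move in this assay is no change at the digits printed from compound 2 to compound 4 (within the scatter) with no firm direction, and nothing beyond the scatter is expected. For compound 4 the estimate is 2.6 and the expected range runs from 2.2 to 3 (an expectation only, until the measurement is in).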

Compound 4, distribution coefficient: 2.5
The estimate for compound 4 lay 0.10 log units above the measured number; measured number inside the range.
By their numbers in this assay, from the lowest: compounds 4, 1, 2 and 3 (each within the scatter of the next).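

The exchange of 2-methylpyridin-4-yl for (pyridin-2-yl)methyl on an oxygen on an aromatic ring, with the same atoms joined differently, gives a number 0.10 log units lower from compound 2 to compound 4 (within the scatter) in this assay, so this place now has a direct exchange on the oxygen itself. Placing (pyridin-2-yl)methoxy where pyridin-3-yl stood on an aromatic carbon gives a number 0.10 log units lower from compound 1 to compound 4 (within the scatter), which together with the first step leaves all three steps among compounds 1, 2 and 4 inside the scatter on this assay. No supporting measurement bears on why these values stay within the scatter.

The compounds shown carry only pyridine-bearing groups at this place, so what this assay does with a carboxylic acid or a saturated amine there remains open. As far as these compounds go, a longer chain between the oxygen and the pyridine ring also remains open.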